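Carbamate Nitrogen Substituent: Cyclohexyl to Benzyl

A few compounds are considered here, and "the series" means these few. Any claim that something is new, unique, unknown or untested is made for them only; others in the source may bear on it.

Compound 1, `C/C(=C\COC(=O)Nc1ccccc1)C1=CC(=O)C(C)(C)O1`, in a functional assay on MOLT-4F cells (Homo sapiens) for inhibition (a lower number here means a stronger inhibitor, a higher number a weaker inhibitor), gives a limit of > 200 ug/mL.
Compound 2, `C=CCNC(=O)OC/C=C(\C)C1=CC(=O)C(C)(C)O1`, gives 7.7 ug/mL.
Compound 3, `C/C(=C\COC(=O)NC1CCCCC1)C1=CC(=O)C(C)(C)O1`, gives 3.4 ug/mL.

Among the numbers shown, compound 3 gives the lowest, with compound 2 nearest: a 2.3-fold lower number from compound 2 to compound 3 (0.36 log units; beyond the scatter). The value of compound 1 is a limit, not a number, known only as the limit of > 200 ug/mL in this assay, at which 1 of the 3 values shown sits. Compound 4, `C/C(=C\COC(=O)NCc1ccccc1)C1=CC(=O)C(C)(C)O1`, is not yet measured; it differs from compound 3 as benzyl in place of cyclohexyl on an amide-type nitrogen. The measured steps on this nitrogen were an at least 25-fold lower number from compound 1 to compound 2 (1.41 log units; beyond the scatter) and an at least 58-fold lower number from compound 1 to compound 3 (1.76 log units; beyond the scatter), both large, and the smaller 2.3-fold lower number from compound 2 to compound 3 (0.36 log units; beyond the scatter). Compound 4 resembles compound 2 in carrying a chain carbon on the nitrogen and compound 1 in holding an aromatic ring. The expected step is therefore a 1.8-fold higher number from compound 3 to compound 4 (0.25 log units; within the scatter), a modest rise. Compound 4 is estimated at 6 ug/mL, between 1.5 ug/mL and 25 ug/mL.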

Compound 4, half-maximal inhibitory concentration: 6 ug/mL
Estimate against measurement, compound 4: no gap at the digits printed; the range from low to high includes it.
By their numbers in this assay, from the lowest: compounds 3, 4 and 2 (each within the scatter of the next, the first and the last beyond it). At a limit, above all of these: compound 1.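

With a saturated chain carbon bound to the amide-type nitrogen and carrying the phenyl, an aromatic ring no longer goes with lost inhibition (an at least 33-fold lower number from compound 1 to compound 4 (1.52 log units; beyond the scatter)). Benzyl sits level with both non-aromatic groups, cyclohexyl (a 1.8-fold higher number from compound 3 to compound 4 (0.25 log units; within the scatter)) and allyl (a 1.3-fold lower number from compound 2 to compound 4 (0.11 log units; within the scatter)), with neither step beyond the scatter. The large step is only a bound, since compound 1 stands at a limit: (the limit of > 200 ug/mL in this assay, at which 1 of the 4 values shown sits). From the compounds shown here alone, whether a longer chain, such as phenethyl, holds this level stays open. So does the effect of a carboxylic acid or an amine on the benzyl ring.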